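Replacing 4-chlorophenyl on an aromatic nitrogen

The source may report more compounds than this note shows. Statements on the series, on what has been measured and on what is new or still open speak of the compounds shown alone.

In a functional assay on MCF7 cells (Homo sapiens) for cytotoxicity, read by MTT assay, with a stated time of 72 h (on this read-out lower numbers stand for stronger inhibition and higher numbers for weaker inhibition), compound 1 (`Cn1ccc2c(Oc3ccc(NC(=O)c4cc5cccnc5n(-c5ccccc5)c4=O)cc3F)ncnc21`) gives 73400 nM as its reading, and compound 2 (`Cn1ccc2c(Oc3ccc(NC(=O)c4cc5cccnc5n(-c5ccc(Cl)cc5)c4=O)cc3F)ncnc21`) gives 75000 nM on the same scale. Compound 2 thus stands level with compound 1, and both numbers are large for a read-out on which lower means stronger inhibition.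

Compound 3 (`Cn1ccc2c(Oc3ccc(NC(=O)c4cc5cccnc5n(-c5ccc(C(F)(F)F)cc5Cl)c4=O)cc3F)ncnc21`) carries 2-chloro-4-(trifluoromethyl)phenyl in place of 4-chlorophenyl on an aromatic nitrogen. For the measured compounds named here, the one measured step that bears on this change is a 1.0-fold higher number from compound 1 to compound 2 (0.01 log units; within the scatter) for chloro in place of hydrogen on an aromatic carbon, so a move beyond the scatter is not expected for compound 3 in this assay from this exchange. Going by the values given here, that is thin evidence, as no measured compound carries trifluoromethyl and neither measured compound has the new arrangement of groups on this ring. The expected change is a 1.2-fold lower number from compound 2 to compound 3 (0.06 log units; within the scatter) and no more than that. Compound 3 is estimated at 65000 nM with a range of 25000 nM to 130000 nM as the expected spread.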

Compound 3, half-maximal inhibitory concentration: "not active" (no number reported)
No number was reported for compound 3, and the estimate cannot be compared.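

In this assay, for the compounds shown here, compound 3 is reported as not active, without a number, and no step from compound 2 to compound 3 can be read. No measurement shown here offers an explanation for this result. The compounds shown leave open where compound 3 stands on this scale relative to compound 2.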